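Adding a Methoxy to the Phenyl of Compound 2

The compounds below may be only part of what the source reports. "The series", "measured", "known", "first", "only" and "open" are said of these compounds alone.

Compound 1 `COc1ccc2c(c1)c(C1CC(c3ccccc3)=NN1C(=O)c1cccnc1)cn2C`: > 10000 nM (a limit)
Compound 2 `COc1ccc2c(c1)c(C1CC(c3ccccc3)=NN1C(=O)c1ccc(OC)nc1)cn2C`: 1110 nM

Among the measured compounds shown here, in a functional assay on A549 cells (Homo sapiens) for inhibition, read by MTT assay, with a stated time of 48 h (a higher number here means a weaker inhibitor of growth, a lower number a stronger inhibitor of growth), compound 2 gives 1110 nM, the only actual number so far. For compound 1 the reading is a limit, > 10000 nM.

Compound 3 `COc1ccc(C2=NN(C(=O)c3ccc(OC)nc3)C(c3cn(C)c4ccc(OC)cc34)C2)cc1` is still to be measured. It departs from compound 2 in one place, phenyl to 4-methoxyphenyl: methoxy in place of hydrogen on an aromatic carbon.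

For the measured compounds named here, only one measured step bears on this change. It is also methoxy in place of hydrogen on an aromatic carbon, and it gave an at least 9.0-fold lower number from compound 1 to compound 2 (0.95 log units; beyond the scatter). On these data alone, that step lies elsewhere in the molecule, however, and its full size is unknown since one end is a limit. It therefore offers only weak guidance for the new position. In this assay a small shift towards a lower number is expected, most likely within the scatter and well short of that earlier step. The estimated change is a 1.6-fold lower number from compound 2 to compound 3 (0.20 log units; within the scatter). For compound 3 the expected value is 700 nM, with an estimated range of 200 nM to 3000 nM.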

Compound 3, concentration for 50% growth inhibition: 450 nM
The estimate for compound 3 lay 1.6-fold (0.19 log units) above the measured number, within the range that was stated.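

Going from phenyl to 4-methoxyphenyl gives a 2.5-fold lower number from compound 2 to compound 3 (0.39 log units; beyond the scatter) in this assay, so this position, on a six-membered aromatic ring of carbon only and para to a large group, responds to methoxy in place of hydrogen. The earlier compounds shown here showed this kind of change at only one other place in the molecule, and the two steps now run the same way: an at least 9.0-fold lower number from compound 1 to compound 2 (0.95 log units; beyond the scatter) is the other one. Compound 1 stands at a limit and not at a number, so the size of its step remains unknown and the two steps cannot be ranked against each other: the limit of > 10000 nM in this assay, at which 1 of the 3 values shown sits.

The compounds shown leave open whether this position would accept a group other than methoxy, such as fluorine, a hydroxyl or an amine, and whether a longer chain such as ethoxy would carry the step further. On these data alone, it also remains open whether the change from phenyl to 4-methoxyphenyl would give a similar step on the core of compound 1, without the methoxy on the other ring.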